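A Hydroxy for a Chloro at the Assay Limit

The source may hold more compounds than are shown below. What is called first, only, known or untested is meant among the compounds shown, and "the series" means these compounds.

In a functional assay on SK-OV-3 cells (Homo sapiens) for antiproliferative activity, read by MTT assay, with a stated time of 24 h (a lower number here means a stronger inhibitor, a higher number a weaker inhibitor), compound 1 `COc1ccc(C(=O)/C=C/c2ccc(N(C)C)cc2)c2c1C=CC(C)(C)O2`, which carries a 4-(dimethylamino)phenyl group, gives 2750 nM. Compound 2 `COc1ccc(C(=O)/C=C/c2ccsc2)c2c1C=CC(C)(C)O2` is recorded only as a limit, > 10000 nM. Compound 3 `COc1ccc(C(=O)/C=C/c2cccc(Cl)c2)c2c1C=CC(C)(C)O2` is also recorded only as a limit, > 10000 nM, so it has no exact place on the scale.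

Compound 4 `COc1ccc(C(=O)/C=C/c2cccc(O)c2)c2c1C=CC(C)(C)O2` keeps the shared core and changes one group: hydroxy in place of chloro on an aromatic carbon. This is 3-chlorophenyl to 3-hydroxyphenyl, with hydroxy in place of chloro on an aromatic carbon, meta to a large group. For the measured compounds named here, no measured step makes this exchange. The nearest evidence is an at least 3.6-fold higher number from compound 1 to compound 3 (0.56 log units; beyond the scatter) and an at least 3.6-fold higher number from compound 1 to compound 2 (0.56 log units; beyond the scatter). Going by the values given here, both lie beyond the scatter, and both start from compound 1, the only compound with an exact number. The remaining comparison, a step that the two limits leave unreadable from compound 2 to compound 3, cannot be read. Nothing shown therefore points to a large step in this assay. Compound 4 is expected to stay near the limit, with at most a modest move towards a lower number, and another limit is slightly more likely than not. The estimated step is an at least 1.2-fold lower number from compound 3 to compound 4 (0.09 log units; that floor lies within the scatter). For compound 4 the estimated value is 8000 nM, with an expected range from 2500 nM to 20000 nM.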

Compound 4, half-maximal inhibitory concentration: > 10000 nM
Compound 4 ended at the assay's limit (the forecaster's own chance of this, stated with the estimate: 55%); at least 1.2-fold (0.09 log units) between middle value and limit.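

In this assay, the change from chloro to hydroxy on this aromatic carbon leaves compound 4 with a limit rather than a number, as for compound 3, and none of the steps between compound 2, compound 3 and compound 4 can be read. For the compounds shown here, what this adds is that a hydroxy, with its hydrogen-bond donor and acceptor in place of a chloro that has neither, does not lift compound 4 off the recorded limit: the limit of > 10000 nM in this assay, at which 3 of the 4 values shown sit. The only readable new step is an at least 3.6-fold higher number from compound 1 to compound 4 (0.56 log units; beyond the scatter), so 3-hydroxyphenyl joins 3-chlorophenyl and thiophen-3-yl among the groups without an exact value, and 4-(dimethylamino)phenyl remains the only group here with one.

Going by these compounds, how far compound 3 and compound 4 lie past the limit remains open, so the size and even the direction of the exchange from chloro to hydroxy are unknown. Also open, on these data alone, is whether an amino group or a carboxylic acid on the same aromatic carbon, meta to a large group, would give a value inside the readable range.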